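From Nitrile Chain to Methoxymethyl on a Shared Core

This account rests on a few compounds, and the source may have more. Where it says the series, first, only, none or still open, it means among the compounds named here.

Compound 1 `Cc1nc2c(OCc3ccccc3)cccn2c1C(N)=O`: 2%
Compound 2 `Cc1nc2c(OCc3ccccc3)cccn2c1CCC#N`: 20%

In a functional assay on the whole organism (stomach) for inhibition, with Canis familiaris (Canis lupus familiaris) as the target, at a dose of 5 mg/kg by the intravenous route (a higher number here means a stronger effect of the compound at the dose given, a lower number a weaker effect), compound 2 gives 20%, the higher of the two numbers, while compound 1 gives 2%. For the measured compounds named here, the one measured step, a number 18 percentage points higher from compound 1 to compound 2 (beyond the scatter), swaps a different group and does not bear on the change to compound 3 `COCc1c(C)nc2c(OCc3ccccc3)cccn12`, which is methoxy in place of cyanomethyl on a saturated chain carbon bound to an aromatic carbon. Going by the values given here, no measured step touches this part of the chain, so the direction is uncertain. Compound 3 is therefore expected to stay near that level, with an expected step of a number 5 percentage points lower from compound 2 to compound 3 (within the scatter) that may lie within the scatter. Compound 3 is estimated at 15%, between 0% and 40%.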

Compound 3, a percentage reported as inhibition, in the whole organism at one dose (the size of the read-out at that dose, not a potency): 29%
Beside the measured number, compound 3's estimate is 14 percentage points below it; the measured number falls inside the stated range.
By their numbers in this assay, from the lowest: compound 1; then compounds 2 and 3 (each within the scatter of the next).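

In this assay, methoxy in place of cyanomethyl on a saturated chain carbon bound to an aromatic carbon gives a number 9 percentage points higher from compound 2 to compound 3 (within the scatter) and so does not separate the 2-cyanoethyl and methoxymethyl groups. Methoxymethyl in place of carbamoyl on an aromatic carbon gives a number 27 percentage points higher from compound 1 to compound 3 (beyond the scatter) and shows that a chain without the triple bond also stands clear of compound 1. Nothing available explains these readings.

The compounds shown leave open whether an amine, a carboxylic acid or a longer ether chain at this place would stand clear of compound 3.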